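Capping the free amine: a cytotoxicity estimate for compound 3

The compounds below may be only part of what the source reports. "The series", "measured", "known", "first", "only" and "open" are said of these compounds alone.

Measured so far:
Compound 1 `COC(=O)C[C@H](NC(=O)OC(C)(C)C)C(=O)N(Cc1ccc(F)cc1)C1(C(=O)NCS(=O)(=O)c2ccc(C)cc2)CCN(Cc2ccccc2)CC1` — 4000 nM
Compound 2 `COC(=O)C[C@H](N)C(=O)N(Cc1ccc(F)cc1)C1(C(=O)NCc2ccccc2)CCN(Cc2ccccc2)CC1` — 60000 nM

Two compounds have been examined in an ADME assay on MDCK cells (Canis lupus familiaris) for cytotoxicity, read by microscopy, with a stated time of 72 h; a higher number here means that more compound is tolerated, a lower number that less compound is tolerated. Compound 1 `COC(=O)C[C@H](NC(=O)OC(C)(C)C)C(=O)N(Cc1ccc(F)cc1)C1(C(=O)NCS(=O)(=O)c2ccc(C)cc2)CCN(Cc2ccccc2)CC1` gives 4000 nM in this assay. Compound 2 `COC(=O)C[C@H](N)C(=O)N(Cc1ccc(F)cc1)C1(C(=O)NCc2ccccc2)CCN(Cc2ccccc2)CC1`, which carries a free amine, gives 60000 nM and so stands at the higher of the two numbers, a gap to compound 1 that lies beyond the scatter. Going by the values given here, the two compounds differ in several places at once, so their values show only that compound 2 is tolerated at a higher concentration than compound 1, not which change is responsible.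

Compound 3 `COC(=O)C[C@H](NC(=O)OCc1ccccc1)C(=O)N(Cc1ccc(F)cc1)C1(C(=O)NCc2ccccc2)CCN(Cc2ccccc2)CC1` has not yet been measured. It differs from compound 2 in one place: benzyloxycarbonyl in place of hydrogen on an amine nitrogen, the change reading amino to (benzyloxycarbonyl)amino. Since compound 1, whose amine is likewise acylated, is tolerated less well at 4000 nM, the expectation for compound 3 is a downward step in this assay, of the size a 3.0-fold lower number from compound 2 to compound 3 (0.48 log units; beyond the scatter), though with the uncertainty that no single-change comparison has been measured. Compound 3 is therefore expected to give about 20000 nM, within a range from 6000 nM to 60000 nM.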

Compound 3, minimum cytotoxic concentration: 2600 nM
The estimate for compound 3 lay 7.7-fold (0.89 log units) above the measured number, outside the stated range (below it).
By their numbers in this assay, from the lowest: compounds 3 and 1 (each within the scatter of the next); then compound 2.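

In this assay, the amine nitrogen that is free in compound 2 turns out to be a place where a single change moves the number strongly: putting benzyloxycarbonyl in place of hydrogen there gives a 23-fold lower number from compound 2 to compound 3 (1.36 log units; beyond the scatter). Going by these compounds alone, this is the first comparison that isolates one change, so the shift can be tied to this substitution on an otherwise unchanged core, which the earlier pair, differing in several places at once, did not allow. Nothing available here accounts for why the number falls with this group in place.

The step covers the whole benzyloxycarbonyl group at once, with its carbonyl, its oxygens and its aromatic ring entering together, so the compounds shown do not tell which part of it goes with the lower number. From the compounds shown here alone, it also remains open whether a small acetyl group or a plain methyl on the same amine nitrogen would lower the number as far, or whether the free amino group itself is what goes with the higher number in compound 2.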